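The source may report more compounds than this note shows. Statements on the series, on what has been measured and on what is new or still open speak of the compounds shown alone.

Measured in a functional assay on SUP-B15 cells (Homo sapiens) for antiproliferative activity, with a stated time of 72 h; a higher number here means that more compound is needed for the effect, a lower number that less compound is needed:

- compound 1 `COc1ccc(-c2c(I)c(=O)c3c(OC)cc(OC)cc3n2S(=O)(=O)c2ccc(OC)cc2)cc1`: 12300 nM
- compound 2 `COc1ccc(-c2cc(=O)c3c(OC)cc(OC)cc3n2S(=O)(=O)c2ccc([N+](=O)[O-])cc2)cc1`: 17100 nM
- compound 3 `COc1cc(OC)c2c(=O)cc(C(=O)Nc3ccc(C4CCCCC4)cc3)[nH]c2c1`: > 43100 nM (a limit of the assay, not a number)

Compound 1 and compound 2 share a sulfonyl-bearing core and give numbers of the same order in this assay. Among the measured compounds shown here, compound 3 carries an amide instead and stands apart: it sits at the limit of > 43100 nM in this assay, at which 1 of the 3 values shown sits, so nothing more than that limit is known for it, and no measured step leads from it to any neighbour.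

Compound 4 `COc1cc(OC)c2c(=O)cc(C(=O)Nc3ccc(Oc4cccnc4)cc3)[nH]c2c1` is the next member of the amide branch. For the measured compounds named here, its single change from compound 3 is (pyridin-3-yl)oxy in place of cyclohexyl on an aromatic carbon. Going by the values given here, no measured step of this kind exists in the set, so the expectation rests only on the standing of compound 3 at its limit. For compound 4 the step from its parent is expected to be an at least 1.7-fold lower number from compound 3 to compound 4 (0.23 log units; that floor lies within the scatter), that is, no move beyond the scatter, with a real chance that the assay again reports only a limit. Compound 4 is therefore estimated at 25000 nM in this assay, within 5000 nM to 60000 nM.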

Compound 4, half-maximal effective concentration: > 32100 nM
Compound 4: only a limit was reported; the forecaster's own chance of this, stated with the estimate: 45%; middle value at least 1.2-fold (0.10 log units) from the limit.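

In this assay compound 3 gives only a limit, > 43100 nM. Among the compounds shown here, compound 4 also gives only a limit, > 32100 nM, so no step between compound 3 and compound 4 can be read. The compounds shown leave open whether (pyridin-3-yl)oxy in place of cyclohexyl on an aromatic carbon changes the number at all.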